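This account rests on a few compounds, and the source may have more. Where it says the series, first, only, none or still open, it means among the compounds named here.

The measured compounds and their values:

Compound 1, `CCc1ccc(-c2nc3cc([N+](=O)[O-])ccc3[nH]2)nc1`, gives -5%.
Compound 2, `CCc1cccc(-c2nc3cc(Cl)ccc3[nH]2)n1`, gives 3%.
Compound 3, `CCc1ccc(-c2nc3ccccc3n2C)nc1`, gives 5%.

These three were measured in a functional assay on the whole organism with Rattus norvegicus as the target, read by paw edema, with a stated time of 3 h, at a dose of 100 mg/kg by the oral route; a higher number here means more inhibition at the dose given (going by the name of the read-out), a lower number less inhibition. Compound 3 holds the highest of the three numbers, but its nearest neighbour, compound 2, sits within the scatter of it, and so does compound 1, the furthest of the three. Going by the values given here, nothing among the measured compounds therefore separates one from another, and all three sit close to no inhibition in this assay.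

Compound 4, `CCc1ccc(-c2nc3ccccc3n2Cc2ccccc2)nc1`, has not been measured yet. It differs from compound 3 in one place: phenyl in place of hydrogen on a saturated chain carbon bound to an aromatic nitrogen. Among the compounds with values here, no measured pair shows a step of this kind, so the data give no guide to its effect. Given that compounds 1, 2 and 3 all fall within the scatter of one another near zero, the expected step of a number 3 percentage points higher from compound 3 to compound 4 (within the scatter) is one that stays within the scatter, with no direction favoured. Compound 4 is accordingly estimated at 8%, with a range from -10% to 28%, a figure that would leave it alongside the three measured compounds rather than apart from them.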

Compound 4, a percentage reported as inhibition, in the whole organism at one dose (the size of the read-out at that dose, not a potency): -18%
Beside the measured number, compound 4's estimate is 26 percentage points above it, outside the stated range (below it).
By their numbers in this assay, from the lowest: compound 4; then compounds 1, 2 and 3 (each within the scatter of the next).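

Going by these compounds alone, the change from methyl to benzyl, on a saturated chain carbon bound to an aromatic nitrogen, is the first in this set whose effect can be read, and in this assay it gives a number 23 percentage points lower from compound 3 to compound 4 (beyond the scatter). The position therefore responds to what is placed on it, and adding phenyl here moves the result downward, so that compound 4, at -18%, falls on the negative side of zero, whereas compound 3 stays close to no inhibition. Nothing available bears on the reason for this step, so the data record only that it occurs.

A single pair cannot tell whether the step follows from the aromatic ring itself or from the larger group as a whole, and a propyl or longer chain, a cyclohexylmethyl group, or a benzyl group bearing an amine or a carboxylic acid at the same place would help to separate the two. As far as these compounds go, it also remains open whether the same change would give a similar step on a core carrying a chlorine or a nitro group, as compounds 1 and 2 do.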